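Swapping the amide aryl group in an antiproliferative quinoline series

The source may report more compounds than this note shows. Statements on the series, on what has been measured and on what is new or still open speak of the compounds shown alone.

Measured compounds:
- compound 1 `CCN1CCN(c2cc(C)c3cc(NC(=O)c4cccc(C)c4)ccc3n2)CC1`: 7800 nM
- compound 2 `CCN(CC)c1cc(C)c2cc(NC(=O)c3ccc(Cl)c(Cl)c3)ccc2n1`: limit, > 50000 nM
- compound 3 `Cc1cc(N2CCN(C(C)C)CC2)nc2ccc(NC(=O)c3ccc(Cl)c(Cl)c3)cc12`: 1710 nM

In a functional assay on MCF7 cells (Homo sapiens) for antiproliferative activity, read by MTT assay, with a stated time of 72 h (a lower number here means a stronger inhibitor, a higher number a weaker inhibitor), compound 1 gives 7800 nM. Going by the values given here, compound 3 gives 1710 nM in this assay, so compound 1 stands highest of the two numbers known, with compound 3 the nearest neighbour. For compound 2 this assay reports only a limit, > 50000 nM, not a number; the same holds for (the limit of > 50000 nM in this assay, at which 1 of the 3 values shown sits).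

Among the compounds with values here, the only measured step, an at least 29-fold lower number from compound 2 to compound 3 (1.46 log units; beyond the scatter), concerns the amine on the shared core, not the amide side. Compound 4 `CCN1CCN(c2cc(C)c3cc(NC(=O)c4cc5ccccc5[nH]4)ccc3n2)CC1` differs from compound 1 on the other side of the molecule: 1H-indol-2-yl in place of 3-methylphenyl on a carbonyl carbon. Within the data shown here, no measured step bears on that change, so nothing here tells its direction or size. The expectation for compound 4 is therefore a step of a 1.6-fold lower number from compound 1 to compound 4 (0.19 log units; within the scatter), that is, little movement beyond the scatter. Compound 4 is estimated at 5000 nM, with a range from 900 nM to 25000 nM.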

Compound 4, half-maximal inhibitory concentration: 2950 nM
Compound 4: middle estimate off by 1.7-fold (0.23 log units), on the high side; low and high end bracket the measured number.
By their numbers in this assay, from the lowest: compounds 3 and 4 (each within the scatter of the next); then compound 1. At a limit, above all of these: compound 2.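

Going by these compounds alone, the amide side of the molecule also moves the number in this assay, which the earlier compounds could not show, since their only measured step lay on the amine side: 1H-indol-2-yl in place of 3-methylphenyl on the carbonyl carbon gives a 2.6-fold lower number from compound 1 to compound 4 (0.42 log units; beyond the scatter). The change is modest, but it lies beyond the scatter, and it brings a second ring and a hydrogen-bond donor that 3-methylphenyl lacks. Nothing shown here explains this step.

The compounds shown leave open whether the extra ring or the ring nitrogen with its hydrogen accounts for the step, since both change together. A 2-naphthyl group, with two rings of carbon only, would separate the two, and a 1-methyl-1H-indol-2-yl group would test the hydrogen alone.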